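The compounds below may be only part of what the source reports. "The series", "measured", "known", "first", "only" and "open" are said of these compounds alone.

In a functional assay on MCF7 cells (Homo sapiens) for cytotoxicity, read by WST assay, with a stated time of 72 h (on this read-out lower numbers stand for stronger inhibition and higher numbers for weaker inhibition), compound 1 `Cc1cccc2c1NC(=O)C2(c1ccc(O)cc1)C1CCCCCC1` returns only a limit, > 1000 nM. Within the data shown here, compound 2 `Cc1cc(C)c2c(c1)C(c1ccc(O)cc1)(c1ccc(F)cc1)C(=O)N2` gives 40 nM, the only actual number available on this read-out. Compound 3 `Cc1cc(C)c2c(c1)C(c1ccc(O)cc1)(C1CCCCCC1)C(=O)N2` has cycloheptyl in place of 4-fluorophenyl on a saturated ring carbon of compound 2: cycloheptyl in place of 4-fluorophenyl on a saturated ring carbon. Among the measured compounds shown here, no measured pair of compounds isolates this change, so any expectation remains loose. The one available hint is that compound 1, which also bears cycloheptyl, stops at the limit of > 1000 nM. On that basis, a weakening beyond the usual scatter is expected in this assay, rather than a gain or no change. The estimated weakening a 5.0-fold higher number from compound 2 to compound 3 (0.70 log units; beyond the scatter) is substantial but leaves a measurable value the more likely outcome. For compound 3, the expected value is 200 nM, with an estimated range of 40 nM to 1000 nM.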

Compound 3, half-maximal inhibitory concentration: > 1000 nM
Compound 3 was reported as a limit; the forecaster's own chance of this, stated with the estimate: 25%; at least 5.0-fold (0.69 log units) between middle value and limit.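

Among these compounds, putting cycloheptyl in place of 4-fluorophenyl on a saturated ring carbon gives, in this assay, an at least 25-fold higher number from compound 2 to compound 3 (1.39 log units; beyond the scatter), the first step that isolates this position. The change replaces a six-membered aromatic ring of carbon only with a seven-membered non-aromatic ring of carbon only, and neither group has hydrogen-bond donors or acceptors. The step gives only a lower bound on the loss, since its end point is a limit: the limit of > 1000 nM in this assay, at which 2 of the 3 values shown sit.

The step from compound 1 to compound 3, with methyl in place of hydrogen on an aromatic carbon, cannot be read, as both values are limits. On these data alone, it also remains open whether unsubstituted phenyl, cyclopentyl or a piperidine ring at this carbon would give a measurable value on this read-out.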